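Bromofuranone series: exocyclic double-bond geometry step

This account rests on a few compounds, and the source may have more. Where it says the series, first, only, none or still open, it means among the compounds named here.

Going by the values given here, compound 1 `CCC[C@@H](OC(C)=O)C1=C(Br)/C(=C/Br)OC1=O` and compound 2 `CCC[C@@H](O)C1=C(Br)/C(=C\Br)OC1=O` are the two measured members of this set. In a functional assay on KB cells (Homo sapiens) for cytotoxicity (a lower number here means that less compound is needed, a higher number that more compound is needed for the effect), compound 1 gives 1 ug/mL, and in this assay compound 2 gives 1.1 ug/mL. Compound 2 holds the higher of the two numbers, yet its nearest neighbour, compound 1, sits within the scatter of it, so no order can be read between them. The next member, compound 3 `CCC[C@@H](O)C1=C(Br)/C(=C/Br)OC1=O`, awaits measurement in this assay. Relative to compound 2 the change is the two compounds have the same atoms and bonds and differ only in configuration as drawn: 1 of 2 stereo elements differ; a double bond is drawn E in compound 2 and Z in compound 3. Among the compounds with values here, no step between measured compounds isolates this change, so the measured pair gives no direct guide to its size. With the same atoms and bonds retained, the step in this assay from compound 2 to compound 3 is expected to be of no clear size beyond the scatter, in either direction. Compound 3 is estimated at 1.1 ug/mL, within 0.5 ug/mL to 2.5 ug/mL. The expected step is no change at the digits printed from compound 2 to compound 3 (within the scatter).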

Compound 3, concentration for half-maximal effect: 0.1 ug/mL
Beside the measured number, compound 3's estimate is 11-fold (1.04 log units) above it, outside the stated range (below it).
By their numbers in this assay, from the lowest: compound 3; then compounds 1 and 2 (each within the scatter of the next).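

In this assay the geometry of the exocyclic double bond proves to be a large lever on its own, with an 11-fold lower number from compound 2 to compound 3 (1.04 log units; beyond the scatter), and nothing else in the structure can account for that step: the fact that compounds 2 and 3 differ only in the configuration as drawn
With the double bond drawn Z in both compounds, the oxygen substituent also counts, with hydrogen in place of acetyl giving a 10-fold lower number from compound 1 to compound 3 (1.00 log units; beyond the scatter).
Neither effect could be read from compounds 1 and 2 alone, since they differ in two places and their values lie within the scatter.

Going by these compounds, whether hydrogen in place of acetyl gives a step of similar size with the double bond drawn E remains open, as does the effect of inverting the saturated carbon. Also open, on these data alone, is how compound 3 would respond to a longer chain on that carbon or to chlorine in place of bromine.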